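Adding an Amino Group to Compound 2

This account rests on a few compounds, and the source may have more. Where it says the series, first, only, none or still open, it means among the compounds named here.

Compound 1 `Cc1ncc([N+](=O)[O-])n1CCSc1nnc(-c2ccccn2)o1`: 30000 nM
Compound 2 `Cc1ncc([N+](=O)[O-])n1CCSc1nnc(-c2cccnc2)o1`: 31600 nM

In a functional assay on SGC-7901 cells (Homo sapiens) for cytotoxicity, read by MTT assay, with a stated time of 48 h (a lower number here means a stronger inhibitor, a higher number a weaker inhibitor), compound 2 gives 31600 nM, which stands within the scatter of compound 1. Compound 3 `Cc1ncc([N+](=O)[O-])n1CCSc1nnc(-c2ccc(N)nc2)o1` differs from compound 2 by amino in place of hydrogen on an aromatic carbon. Among the measured compounds shown here, the only measured step, a 1.1-fold higher number from compound 1 to compound 2 (0.02 log units; within the scatter), swapped pyridin-2-yl for pyridin-3-yl and stayed within the scatter. For the measured compounds named here, no measured step involves an amino group, so the data suggest no direction. The expected change is a 1.3-fold lower number from compound 2 to compound 3 (0.10 log units; within the scatter), none beyond the scatter. In this assay compound 3 is estimated at 25000 nM, with an expected range of 8000 nM to 70000 nM.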

Compound 3, half-maximal inhibitory concentration: 30900 nM
Compound 3: middle estimate off by 1.2-fold (0.09 log units), on the low side; the measured number falls inside the stated range.
By their numbers in this assay, from the lowest: compounds 1, 3 and 2 (each within the scatter of the next).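

In this assay, amino in place of hydrogen next to the ring nitrogen leaves the number within the scatter (a 1.0-fold lower number from compound 2 to compound 3 (0.01 log units; within the scatter)), so this position accepts the amino group without a measurable shift. The step from the unsubstituted pyridin-2-yl also stays within the scatter (a 1.0-fold higher number from compound 1 to compound 3 (0.01 log units; within the scatter)), and all three compounds remain level. No evidence is available to explain this flat result.

As far as these compounds go, whether a dimethylamino group, a carboxylic acid or a longer chain at this position would move the number remains open, as does the effect of an amine on the pyridin-2-yl ring of compound 1.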